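Fluoro in place of hydrogen on the pyridine-free core of compound 1

A few compounds are considered here, and "the series" means these few. Any claim that something is new, unique, unknown or untested is made for them only; others in the source may bear on it.

Measured compounds in a functional assay on A-431 cells (Homo sapiens) for cytotoxicity, read by MTT assay, with a stated time of 72 h, tested at 10 uM; a lower number here means less inhibition of growth, a higher number more inhibition of growth at the concentration tested:
compound 1 `N/C(=N\NC(=S)N1CCCCCC1)c1ccccn1` — 67%
compound 2 `Cc1ccnc(/C(N)=N/NC(=S)N2CCCCCC2)c1` — 55.5%
compound 3 `Cc1cccc(/C(N)=N/NC(=S)N2CCCCCC2)n1` — 45.8%

Compound 1 gives the highest of the three numbers in this assay; compound 2 stands nearest to it and compound 3 furthest, both lower by more than the usual scatter.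

Compound 4 `N/C(=N\NC(=S)N1CCCCCC1)c1ccc(F)cn1` differs from compound 1 by fluoro in place of hydrogen on an aromatic carbon. Among the compounds with values here, two measured steps bear on this change, though only loosely: both swap a hydrogen for a methyl at an aromatic carbon of the same ring, giving a number 11.5 percentage points lower from compound 1 to compound 2 (beyond the scatter) and a number 21.2 percentage points lower from compound 1 to compound 3 (beyond the scatter). Neither enters a fluoro, and neither occupies the same place as the change in compound 4, so they indicate at most that substitution on this ring has so far pulled the number down by a modest amount.

On that basis, a small downward step is expected for compound 4, estimated as a number 9 percentage points lower from compound 1 to compound 4 (within the scatter), with a real chance that it stays within the scatter. Compound 4 is therefore estimated at 58%, with a range from 40% to 74%.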

Compound 4, percent growth inhibition at one concentration: 64.4%
Compound 4: the middle estimate sits 6.4 percentage points below what was measured; the range from low to high includes it.
By their numbers in this assay, from the lowest: compounds 3, 2, 4 and 1 (each within the scatter of the next, the first and the last beyond it).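

In this assay, placing fluoro on the aromatic carbon two atoms from the ring nitrogen and para to a large group gives a number 2.6 percentage points lower from compound 1 to compound 4 (within the scatter), so this replacement of hydrogen leaves no measurable change at this place. It is the first substitution on this ring shown to stay within the scatter, whereas the two methyl replacements at other places gave a number 11.5 percentage points lower from compound 1 to compound 2 (beyond the scatter) and a number 21.2 percentage points lower from compound 1 to compound 3 (beyond the scatter). The data shown offer no measured explanation for this difference between the steps.

From the compounds shown here alone, it remains open whether methyl at this same place would be tolerated like fluoro, so the influence of the group cannot yet be separated from that of its place. Nor do these compounds show whether chloro, methoxy or an amine at this carbon would keep the number near that of compound 1.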